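Methylamino for methoxy on the long-chain member

The source may report more compounds than this note shows. Statements on the series, on what has been measured and on what is new or still open speak of the compounds shown alone.

Values in a functional assay on HCT-116 cells (Homo sapiens) for antiproliferative activity, read by MTT assay, with a stated time of 48 h (a higher number here means a weaker inhibitor, a lower number a stronger inhibitor), so far:
- compound 1 `CCCCCCCCC(CCO)n1cnc2c(NC)ncnc21` gives 3730 nM
- compound 2 `CCCCCCCCCC(CCO)n1cnc2c(NC)ncnc21` gives 5410 nM
- compound 3 `CCCCCCCCCCCC(CCO)n1cnc2c(OC)ncnc21` gives 8230 nM
- compound 4 `CCCCCCCCCCCC(CCO)n1cnc2c(NC)ncnc21` has no value yet

Compound 3 holds the highest of the three numbers, but only its gap to compound 1 lies beyond the scatter, while its gap to compound 2 lies within it. The move to compound 4 is methylamino in place of methoxy on an aromatic carbon, and the saturated chain stays unchanged: methylamino in place of methoxy on an aromatic carbon is the full count of that difference.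

Within the data shown here, no measured pair isolates this exchange, so its size is unknown. Among the measured compounds shown here, the only measured step, methyl in place of hydrogen on the saturated chain, is a 1.5-fold higher number from compound 1 to compound 2 (0.16 log units; within the scatter) and bears on the exchange only indirectly. It does show that the two methylamino compounds, compound 1 and compound 2, stay close together. Compound 4 combines their methylamino group with the chain of compound 3, so no shift beyond the scatter is expected in this assay, with a slight lean towards a lower number. The expected change is a 1.4-fold lower number from compound 3 to compound 4 (0.14 log units; within the scatter) and remains tentative. For compound 4 the estimated value is 6000 nM with an expected range of 2800 nM to 12000 nM around it.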

Compound 4, half-maximal inhibitory concentration: 15400 nM
Compound 4: middle estimate off by 2.6-fold (0.41 log units), on the low side; the whole stated range lies below it.
By their numbers in this assay, from the lowest: compounds 1, 2, 3 and 4 (each within the scatter of the next, the first and the last beyond it).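

In this assay, methylamino in place of methoxy on an aromatic carbon now has a direct reading, a 1.9-fold higher number from compound 3 to compound 4 (0.27 log units; within the scatter), so this exchange at this position, on this chain, does not move the number beyond the scatter. Among the methylamino compounds, the steps beyond the scatter lie along the saturated chain, with a 2.8-fold higher number from compound 2 to compound 4 (0.45 log units; beyond the scatter) for ethyl in place of hydrogen and a 4.1-fold higher number from compound 1 to compound 4 (0.62 log units; beyond the scatter) for propyl in place of hydrogen, while the smaller chain change in a 1.5-fold higher number from compound 1 to compound 2 (0.16 log units; within the scatter) stays within the scatter. No measurement is available here that accounts for either the exchange or the chain steps.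

Methoxy appears in the compounds shown on a single chain only, so whether the exchange reads the same on the chains of compound 1 and compound 2 remains open. Also open, as far as these compounds go, is how a dimethylamino group or an unsubstituted amine on the same aromatic carbon, or a still longer saturated chain on the shared core, would read in this assay.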